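From pyrrolidin-1-yl to morpholin-4-yl on the carbonyl

This account rests on a few compounds, and the source may have more. Where it says the series, first, only, none or still open, it means among the compounds named here.

Compound 1 `CCCCc1oc2ccccc2c1C(=O)c1ccc(OCC(=O)Nc2ccccc2)cc1` reads > 50000 nM in a functional assay on HL-60 cells (Homo sapiens) for antiproliferative activity, read by MTT assay, with a stated time of 24 h (on this read-out lower numbers stand for stronger inhibition and higher numbers for weaker inhibition), and this reading is a limit of the assay, not a number. Among the compounds with values here, compound 2 `CCCCc1oc2ccccc2c1C(=O)c1ccc(OCCCC(=O)N2CCCC2)cc1` gives 29900 nM in this assay, the only actual number so far, so it has no second number to be ranked against. Compound 3 `CCCCc1oc2ccccc2c1C(=O)c1ccc(OCCCC(=O)N2CCOCC2)cc1` keeps everything in compound 2 except one group: morpholin-4-yl in place of pyrrolidin-1-yl on a carbonyl carbon. Morpholin-4-yl thus takes the place of pyrrolidin-1-yl on a carbonyl carbon. Within the data shown here, only one measured step exists, an at least 1.6-fold lower number from compound 1 to compound 2 (0.22 log units; that floor lies within the scatter). It bears on this change only loosely, since it replaces phenylcarbamoyl rather than the group now exchanged, and its floor lies within the scatter. Among the measured compounds shown here, no measured step covers the exchange itself, so the expectation in this assay rests on compound 2 at 29900 nM, with no shift beyond the scatter in either direction. The expected step is a 1.1-fold higher number from compound 2 to compound 3 (0.04 log units; within the scatter). For compound 3 the estimated value is 33000 nM, with an expected range of 14000 nM to 65000 nM.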

Compound 3, half-maximal inhibitory concentration: 34100 nM
Beside the measured number, compound 3's estimate is 1.0-fold (0.01 log units) below it, and the stated range covers the measured number.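

Within the data shown here, exchanging pyrrolidin-1-yl for morpholin-4-yl on a carbonyl carbon gives the first comparison between two actual numbers in this assay, and the step is a 1.1-fold higher number from compound 2 to compound 3 (0.06 log units; within the scatter). At this place, then, the larger six-membered ring with its ring oxygen and one hydrogen-bond acceptor gives a reading that cannot be told apart from that of the five-membered ring, so the two amides hold no order on this read-out. The other new step is an at least 1.4-fold lower number from compound 1 to compound 3 (0.16 log units; that floor lies within the scatter), which fixes no order either, since its floor lies within the scatter and its starting point is a limit of the assay, not a number: the limit of > 50000 nM in this assay, at which 1 of the 3 values shown sits.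

The compounds shown leave open whether any group on this carbonyl carbon, such as piperidin-1-yl, 4-methylpiperazin-1-yl or a plain dimethylamino group, would move the number beyond the scatter. They also leave open how the chain itself counts, since compound 1 differs from compound 2 and compound 3 in both chain and amide, and a shorter or longer chain carrying the morpholin-4-yl amide would be needed to separate the two.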